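Methoxy for methyl on the pyridine ring of the shared core

The compounds below may be only part of what the source reports. "The series", "measured", "known", "first", "only" and "open" are said of these compounds alone.

Measured compounds:
compound 1, `NC(=O)c1cccc(-c2cnc(C(=O)CCCCCCc3ccccc3)o2)c1`, > 100000 nM
compound 2, `Cc1ccnc(-c2cnc(C(=O)CCCCCCc3ccccc3)o2)c1`, > 100000 nM

Of the compounds shown here, two have been measured in an assay on isolated protein for inhibition of neutral cholesterol ester hydrolase 1 (Homo sapiens); on this read-out higher numbers stand for weaker inhibition and lower numbers for stronger inhibition. Compound 1, `NC(=O)c1cccc(-c2cnc(C(=O)CCCCCCc3ccccc3)o2)c1`, gives only a limit of the assay, > 100000 nM. Compound 2, `Cc1ccnc(-c2cnc(C(=O)CCCCCCc3ccccc3)o2)c1`, also gives only a limit, > 100000 nM. The step that the two limits leave unreadable from compound 1 to compound 2 between them therefore cannot be read, and compound 2 stands at the limit, which is where both values sit (the limit of > 100000 nM in this assay, at which 2 of the 2 values shown sit).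

Compound 3, `COc1ccnc(-c2cnc(C(=O)CCCCCCc3ccccc3)o2)c1`, differs from compound 2 in one place: methoxy in place of methyl on an aromatic carbon. For the measured compounds named here, the one measured step, a step that the two limits leave unreadable from compound 1 to compound 2, concerns a different position and is itself unreadable, so no measured step bears on this change. With compound 2 giving only a limit in this assay , the step that the limit leaves unreadable from compound 2 to compound 3 is expected to leave compound 3 at or near that limit, and no change beyond the scatter can be foreseen in either direction. Compound 3 is estimated to give 150000 nM in this assay , within the range 50000 nM to 500000 nM, most likely again as a limit.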

Compound 3, half-maximal inhibitory concentration: > 100000 nM
Compound 3 was reported as a limit; the forecaster's own chance of this, stated with the estimate: 85%; the middle value is on the limit's open side.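

In this assay compound 3 gives > 100000 nM, which is a limit of the assay. For the compounds shown here, no step from compound 1 or compound 2 to compound 3 can be read, as all the values rest at the same point: the limit of > 100000 nM in this assay, at which 3 of the 3 values shown sit. The compounds shown leave open whether methoxy in place of methyl changes inhibition at all, and how strongly compound 1, compound 2 or compound 3 inhibits.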